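Cyclohexyl to 4-chlorobenzyl on the amide of compound 1

The source may report more compounds than this note shows. Statements on the series, on what has been measured and on what is new or still open speak of the compounds shown alone.

Measured so far:
compound 1, `C=CC1=C(C(=O)NC2CCCCC2)C(c2ccc(OC)c(OC)c2)OC1`: 19100 nM
compound 2, `C=CC1=C(C(=O)NC2CCCCC2)C(c2ccc(OC)cc2)OC1`: > 100000 nM
compound 3, `C=CC1=C(C(=O)NCc2ccccc2)C(c2ccc(F)cc2)OC1`: > 100000 nM

Within the data shown here, in a functional assay on SW480 cells (Homo sapiens) for cytotoxicity, read by MTT assay, with a stated time of 24 h (a lower number here means a stronger inhibitor, a higher number a weaker inhibitor), compound 1 gives 19100 nM, the only number in the set. For compound 2 this assay reports only a limit, > 100000 nM. For compound 3 it likewise reports only a limit, > 100000 nM. Among the measured compounds shown here, the single step that can be read, an at least 5.2-fold higher number from compound 1 to compound 2 (0.71 log units; beyond the scatter), follows the loss of one methoxy from the aromatic ring and runs against a limit, as does the entry for compound 3; the limit itself is the limit of > 100000 nM in this assay, at which 2 of the 3 values shown sit, and 2 of the 3 entries sit on it.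

Compound 4, `C=CC1=C(C(=O)NCc2ccc(Cl)cc2)C(c2ccc(OC)c(OC)c2)OC1`, keeps the dimethoxy aryl of compound 1 and changes only the amide substituent: 4-chlorobenzyl in place of cyclohexyl on an amide-type nitrogen. For the measured compounds named here, no measured step covers this change. Compound 3 carries a benzyl amide, but it also carries a different aryl and gives only a limit, so it does not isolate the amide change. With the aryl that gave a number retained, a step near zero or modestly weakening is expected from compound 1, a 1.5-fold higher number from compound 1 to compound 4 (0.17 log units; within the scatter). Compound 4 is therefore estimated at 28000 nM, within 8000 nM to 100000 nM.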

Compound 4, half-maximal inhibitory concentration: > 100000 nM
Compound 4: a limit, no number; the forecaster's own chance of this, stated with the estimate: 30%; middle value at least 3.5-fold (0.55 log units) from the limit.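

With the dimethoxy aryl held fixed, the amide substituent is shown to matter on its own: in this assay, 4-chlorobenzyl in place of cyclohexyl on the amide-type nitrogen gives an at least 5.2-fold higher number from compound 1 to compound 4 (0.71 log units; beyond the scatter). Compound 4 gives only a limit, > 100000 nM, so this step marks a minimum and its full size cannot be read. The dimethoxy aryl alone is therefore not enough for a number among the compounds shown, since compound 1 keeps both it and the cyclohexyl, while a single change at either place, in compound 2 or in compound 4, ends on the same limit: the limit of > 100000 nM in this assay, at which 3 of the 4 values shown sit.

The compounds shown leave open whether the loss goes with the benzyl frame or with the chlorine, a question that a plain benzyl on the amide nitrogen, with the dimethoxy aryl kept, would separate. Also open, from the compounds shown here alone, is how far the cyclohexyl can be varied while a number is retained in this assay, for example with a cyclopentyl ring or an open hexyl chain in its place.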